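Chalcone series with a cyclic urea substituent: chloro removal

A few compounds are considered here, and "the series" means these few. Any claim that something is new, unique, unknown or untested is made for them only; others in the source may bear on it.

Measured so far:
compound 1, `COc1cc(/C=C/C(=O)c2cccc(-n3cc(-c4ccc(Cl)cc4)[nH]c3=O)c2)cc(OC)c1OC`: 30200 nM
compound 2, `COc1cc(/C=C/C(=O)c2cccc(-n3cc(-c4ccccc4)[nH]c3=O)c2)ccc1O`: 1680 nM

In a functional assay on A498 cells (Homo sapiens) for inhibition (on this read-out higher numbers stand for weaker inhibition of growth and lower numbers for stronger inhibition of growth), compound 1 gives 30200 nM, the highest of the two numbers; compound 2 gives 1680 nM, a lower value, beyond the scatter, but the two compounds differ in more than one place, so no single step can be read from them.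

Compound 3, `COc1cc(/C=C/C(=O)c2cccc(-n3cc(-c4ccccc4)[nH]c3=O)c2)cc(OC)c1OC`, differs from compound 1 by hydrogen in place of chloro on an aromatic carbon, leaving the rest of the shared core untouched. Within the data shown here, no measured pair isolates this change. The step of a 2.5-fold lower number from compound 1 to compound 3 (0.40 log units; beyond the scatter) is expected to be a moderate gain in inhibition, with wide uncertainty. Compound 3 is estimated at 12000 nM in this assay, with a range from 3000 nM to 40000 nM.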

Compound 3, concentration for 50% growth inhibition: 2650 nM
For compound 3 the middle estimate is 4.5-fold (0.66 log units) above the measured one; the whole stated range lies above it.
By their numbers in this assay, from the lowest: compounds 2 and 3 (each within the scatter of the next); then compound 1.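

In this assay, among these compounds, the 4-chlorophenyl to phenyl change gives an 11-fold lower number from compound 1 to compound 3 (1.06 log units; beyond the scatter), the first single-place reading. It shows that this aromatic carbon, para to a large group, is sensitive to substitution: hydrogen gives far stronger inhibition of growth than chloro in this pair. No measured information accounts for the size of this step.

As far as these compounds go, it remains open whether any group at this carbon weakens inhibition or only chloro does; fluoro, methoxy, an amine or a carboxylic acid there would test this. From the compounds shown here alone, whether the step holds with other substituents elsewhere on the shared core also remains open.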